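Urea aryl exchange at the limit of the series

This account rests on a few compounds, and the source may have more. Where it says the series, first, only, none or still open, it means among the compounds named here.

Compound 3 `NS(=O)(=O)c1ccc(NC(=O)Nc2cccc(-c3nc(-c4ccc(NC(=O)c5cccnc5)cc4Cl)no3)c2)cc1` returns only a limit in a functional assay on MDA-MB-231 cells (Homo sapiens) for antiproliferative activity, read by MTT assay, with a stated time of 72 h (a higher number here means a weaker inhibitor, a lower number a stronger inhibitor), namely > 10000 nM. Compound 2 `COc1cc(NC(=O)c2cccnc2)ccc1-c1noc(-c2cccc(NS(=O)(=O)c3ccc(NC(C)=O)cc3)c2)n1` likewise sits at a limit there, > 10000 nM. Within the data shown here, compound 1 `CC(=O)Nc1ccc(S(=O)(=O)Nc2cccc(-c3nc(-c4ccc(NC(=O)c5cccnc5)cc4)no3)c2)cc1` is the one member with a number, giving 5200 nM in this assay. Among the measured compounds shown here, the single measured step, an at least 1.9-fold higher number from compound 1 to compound 2 (0.28 log units; that floor lies within the scatter), ends at the limit of > 10000 nM in this assay, at which 2 of the 3 values shown sit, and does not touch the urea aryl group. Compound 4 `CC(=O)Nc1ccc(NC(=O)Nc2cccc(-c3nc(-c4ccc(NC(=O)c5cccnc5)cc4Cl)no3)c2)cc1Br` carries the change (4-acetamido-3-bromophenyl in place of 4-sulfamoylphenyl on an amide-type nitrogen). For the measured compounds named here, no measured step bears on this change; no direction beyond the scatter can be read from the data, and compound 3 standing at the limit leaves its own number open. Compound 4 is expected to remain weak, estimated at 10000 nM with a range of 3000 nM to 30000 nM, which means an estimated step of a number no higher from compound 3 to compound 4 (the limit leaves the size open).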

Compound 4, half-maximal inhibitory concentration: 1000 nM
Estimate against measurement, compound 4: 10-fold (1.00 log units) above, outside the stated range (below it).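

Among these compounds, at the aryl group on the amide-type nitrogen of the urea, this assay does respond to exchange, which no earlier compound showed: an at least 10-fold lower number from compound 3 to compound 4 (1.00 log units; beyond the scatter). Among the compounds shown here, this is the first step that lies beyond the scatter, and it brings a urea member out of the limit. Compound 3 stands at a limit, so the full size of the step stays open: the limit of > 10000 nM in this assay, at which 2 of the 4 values shown sit.

Acetamido and bromine enter together, so their separate contributions remain unresolved. On these data alone, how a 4-aminophenyl or 4-carboxyphenyl group would read on this nitrogen also remains open.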